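A Smaller Amine Ring on the Side Chain

This account rests on a few compounds, and the source may have more. Where it says the series, first, only, none or still open, it means among the compounds named here.

Three compounds that share a long side chain ending in a saturated amine ring were tested in a functional assay on NCI-H460 cells (Homo sapiens) for cytotoxicity, read by MTT assay, with a stated time of 72 h; on this read-out higher numbers stand for weaker inhibition and lower numbers for stronger inhibition. Compound 1 `COc1cc2c(Oc3ccc(NC(=O)c4cc(-c5ccc(C(F)(F)F)cc5)ccn4)cc3F)ccnc2cc1OCCCN1CCCCC1` gives 360 nM. Compound 2 `COc1cc2c(Oc3ccc(NC(=O)c4cc(-c5ccc(C(F)(F)F)cc5)ccn4)cc3F)ccnc2cc1OCCCN1CCCC1` gives 250 nM. The change between these two is pyrrolidin-1-yl in place of piperidin-1-yl on a saturated chain carbon, three bonds along the chain from an oxygen on an aromatic ring, and the step it made is a 1.4-fold lower number from compound 1 to compound 2 (0.16 log units; within the scatter). Compound 3 `COc1cc2c(Oc3ccc(NC(=O)c4nccc(-c5ccccc5)n4)cc3F)ccnc2cc1OCCCN1CCCCC1` gives 330 nM in this assay; the difference between the core of compound 3 and the core of compound 1 is not broken down here, as the two differ in more than one place.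

Compound 4 `COc1cc2c(Oc3ccc(NC(=O)c4nccc(-c5ccccc5)n4)cc3F)ccnc2cc1OCCCN1CCCC1` has not yet been measured. It differs from compound 3 by pyrrolidin-1-yl in place of piperidin-1-yl on a saturated chain carbon, three bonds along the chain from an oxygen on an aromatic ring, the same change as that made from compound 1 to compound 2, at the same place on the chain. For compound 4 the expected step in this assay is a 1.3-fold lower number from compound 3 to compound 4 (0.10 log units; within the scatter), because the earlier step was a 1.4-fold lower number from compound 1 to compound 2 (0.16 log units; within the scatter), a small move that stayed within the usual scatter of the assay. Compound 4 is therefore estimated at 260 nM, with a likely range from 130 nM to 520 nM. This expectation rests on a single earlier example of the same change, so it should be read as a rough forecast rather than a firm prediction.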

Compound 4, half-maximal inhibitory concentration: 1120 nM
Compound 4: middle estimate off by 4.3-fold (0.63 log units), on the low side; measured number outside the range, above it.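

Putting pyrrolidin-1-yl in place of piperidin-1-yl at the end of the side chain gave, in this assay, a 3.4-fold higher number from compound 3 to compound 4 (0.53 log units; beyond the scatter), so on the core of compound 3 the smaller amine ring goes with weaker inhibition. Among the compounds shown here, on the core of compound 1 the same swap gave no change beyond the scatter, and the two results do not agree, so what this swap did on one core could not be carried over to the other as a fixed step: the same change on two cores in this assay, a 1.4-fold lower number (0.16 log units; within the scatter) from compound 1 to compound 2 and a 3.4-fold higher number (0.53 log units; beyond the scatter) from compound 3 to compound 4, 4.9-fold (0.69 log units) apart, beyond the scatter of two such steps These are only two pairs, however, and the two cores differ in more than one place, so they do not show which part of the core matters, why the swap behaves differently, or how it would behave on any third core.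

Going by these compounds, it remains open whether the larger step belongs to the core of compound 3 alone, which a series of cores differing from it in a single place, such as one gaining a trifluoromethyl group, could test. Also open, on these data alone, is how the two cores would respond to other groups at the end of the side chain, such as a morpholine ring or a dimethylamine, or to a longer chain.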